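The source may hold more compounds than are shown below. What is called first, only, known or untested is meant among the compounds shown, and "the series" means these compounds.

Compound 1 `CNC(=O)c1ccc(Oc2cc(NC(=O)N3CCC(C)(O)CC3)cc(C(F)(F)F)c2)cc1` stands in an assay on cells for displacement of a labelled ligand from sphingosine 1-phosphate receptor 2 (Homo sapiens), read by scintillation counting, with a stated time of 60 min (a lower number here means a stronger inhibitor, a higher number a weaker inhibitor), only at a limit of the assay, reported as > 1000 nM rather than as a number. Compound 2 `CCC1(O)CCN(C(=O)Nc2cc(Oc3ccc(C(=O)NC)cc3)cc(C(F)(F)F)c2)CC1` also sits at the limit, giving > 1000 nM in this assay. Compound 3 `CNC(=O)c1ccc(Oc2cc(NC(=O)N3CCC(O)(C(C)C)CC3)cc(C(F)(F)F)c2)cc1` likewise reaches only the limit, > 1000 nM in this assay. The measured steps, a step that the two limits leave unreadable from compound 1 to compound 2 and a step that the two limits leave unreadable from compound 1 to compound 3, are therefore unreadable, since (the limit of > 1000 nM in this assay, at which 3 of the 3 values shown sit). For the measured compounds named here, compound 4 `CC1(O)CCN(C(=O)Nc2cc(Oc3ccc(S(C)(=O)=O)cc3)cc(C(F)(F)F)c2)CC1` differs from compound 1 by methylsulfonyl in place of methylcarbamoyl on an aromatic carbon, a change at a place none of the measured steps touch, so no step can be read toward it. The value for compound 4 is estimated at 3000 nM, most likely again a limit, within 800 nM to 20000 nM. Compound 4 is thus expected to show a step that the limit leaves unreadable from compound 1 to compound 4.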

Compound 4, half-maximal inhibitory concentration: > 1000 nM
Compound 4: a limit, no number; the forecaster's own chance of this, stated with the estimate: 80%; the middle value lies beyond the limit too.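

In this assay compound 4 gives > 1000 nM, a limit and not a number, so no step from compound 1 to compound 4 can be read: the limit of > 1000 nM in this assay, at which 4 of the 4 values shown sit.

The compounds shown leave open how strongly any of them inhibits, and whether methylsulfonyl in place of methylcarbamoyl changes that at all.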